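The source may report more compounds than this note shows. Statements on the series, on what has been measured and on what is new or still open speak of the compounds shown alone.

The series shares a trimethoxyphenyl enone core and varies the aryl group on the carbonyl carbon. Compound 1 `COc1cc(OC)c(OC)cc1/C=C/C(=O)c1ccc(C)cc1` carries a 4-methylphenyl group there, and in a functional assay on MCF7 cells (Homo sapiens) for inhibition, read by MTT assay, with a stated time of 72 h (on this read-out higher numbers stand for weaker inhibition and lower numbers for stronger inhibition), compound 1 gives 33000 nM. Compound 2 `COc1cc(OC)c(OC)cc1/C=C/C(=O)c1cc(OC(C)=O)ccc1OC(C)=O` carries a diacetoxyphenyl group, and in this assay compound 2 gives 63700 nM. Compound 3 `COc1cc(OC)c(OC)cc1/C=C/C(=O)c1cc(Cl)ccc1O` carries a 5-chloro-2-hydroxyphenyl group, and in this assay compound 3 reaches only the limit of the assay, > 150000 nM. Compound 3 thus stands at the weak end of the values shown, and no exact number is known for it, a point on which the limit of > 150000 nM in this assay, at which 1 of the 3 values shown sits, bears. Among the measured compounds shown here, the one step measured in one place is an at least 4.5-fold higher number from compound 1 to compound 3 (0.65 log units; beyond the scatter).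

Compound 4 `COc1cc(OC)c(OC)cc1/C=C/C(=O)c1ccc(O)cc1` is the next member. It differs from compound 3 as follows: 4-hydroxyphenyl in place of 5-chloro-2-hydroxyphenyl on a carbonyl carbon. For the measured compounds named here, the measured step from compound 1 to compound 3 is the only one bearing on this change, and it runs in the opposite sense, since compound 4 returns to a single substituent on the ring, as compound 1 has. The step of an at least 3.7-fold lower number from compound 3 to compound 4 (0.57 log units; beyond the scatter) is therefore expected to bring the number back toward that of compound 1, though a limit is also possible. For compound 4 in this assay the estimate is 40000 nM, expected to lie between 10000 nM and 150000 nM.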

Compound 4, half-maximal inhibitory concentration: 182000 nM
Compound 4: middle estimate off by 4.6-fold (0.66 log units), on the low side; the whole stated range lies below it.
By their numbers in this assay, from the lowest: compounds 1 and 2 (each within the scatter of the next); then compound 4.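

Hydroxy in place of methyl on an aromatic carbon gives a 5.5-fold higher number from compound 1 to compound 4 (0.74 log units; beyond the scatter) in this assay, so this single swap, with no chlorine on the ring, is enough to shift the read-out toward weaker inhibition by more than the scatter. The earlier step to compound 3 changed the ring in more than one way and ended without an exact number, whereas compound 4 ties a measured value to one group on this ring. Compound 3 holds only a limit, > 150000 nM, so the step from it to compound 4 cannot be read, and the effect of going from 5-chloro-2-hydroxyphenyl to 4-hydroxyphenyl stays without a size: the limit of > 150000 nM in this assay, at which 1 of the 4 values shown sits.

The compounds shown leave open whether an amine on this aromatic carbon would move the number in the same sense as the hydroxy of compound 4, or whether it would stay closer to the methyl of compound 1. They also leave open how a carboxylic acid or a longer chain would read in the same place on the ring.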